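The compounds below may be only part of what the source reports. "The series", "measured", "known", "first", "only" and "open" are said of these compounds alone.

The measured compounds:

Compound 1 `CC(C)=CCC1Cc2c(O)cc(=O)n(CCCO)c2CC1(C)C` gives 0% in a functional assay on PANC-1 cells (Homo sapiens) for inhibition, read by MTT assay, with a stated time of 24 h, tested at 10 uM; a lower number here means less inhibition, a higher number more inhibition at the concentration tested (going by the name of the read-out).
Compound 2 `CC(C)=CCOc1cc(=O)n(CCCO)c2c1CC(CC=C(C)C)C(C)(C)C2` gives 7.5%.
Compound 3 `CC(C)=CCC1Cc2c(OCCCNS(=O)(=O)c3ccc(Cl)cc3)cc(=O)n(CCCO)c2CC1(C)C` gives 9.8%.

All three readings are low and lie within the usual scatter of one another, so compound 3 is not set apart from compound 1 or compound 2 by the numbers shown; each compound inhibits the cells only weakly at the concentration tested.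

Compound 4 `CC(C)=CCC1Cc2c(OCCCNC(=O)c3ccc([N+](=O)[O-])cc3)cc(=O)n(CCCO)c2CC1(C)C` is the next compound. It differs from compound 3 in one place: (4-nitrophenyl)carbonyl in place of (4-chlorophenyl)sulfonyl on an amine nitrogen. The shared core, the chain on the ring nitrogen and the linker leading out to the amine nitrogen are unchanged.

Among the compounds with values here, only one measured step is available, a number 7.5 percentage points higher from compound 1 to compound 2 (within the scatter), and it concerns a different part of the molecule, the group on the ring oxygen, not the amine. Within the data shown here, no measured pair shows what replacing the group on the amine nitrogen does. What can be said is that every change seen so far has left the reading within the scatter. The closest relative of compound 4 is compound 3, and compound 3 itself gives 9.8%.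

Compound 4 is therefore expected to stay close to compound 3, with a step of a number 1.2 percentage points higher from compound 3 to compound 4 (within the scatter) that is not expected to go beyond the scatter, and an estimated value of 11%, between 0% and 26%.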

Compound 4, a percentage reported as inhibition, at one concentration (the size of the read-out at that concentration, not a potency): 9.1%
Beside the measured number, compound 4's estimate is 1.9 percentage points above it; low and high end bracket the measured number.
By their numbers in this assay, from the lowest: compounds 1, 2, 4 and 3 (each within the scatter of the next).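

In this assay, within the data shown here, the group on the amine nitrogen can now be judged for the first time: replacing (4-chlorophenyl)sulfonyl with (4-nitrophenyl)carbonyl gives a number 0.7 percentage points lower from compound 3 to compound 4 (within the scatter). Among these compounds, this single swap alters both the link to the amine nitrogen, from sulfonyl to carbonyl, and the substituent on the aromatic ring, from chlorine to nitro, so it cannot show what either part contributes on its own; it shows only that this particular exchange of two whole groups leaves the two readings indistinguishable. Nothing available offers a measured explanation for this result.

The compounds shown leave open whether a much smaller group on the amine nitrogen, such as acetyl, or a free primary amine with no such group at all, would move the reading beyond the scatter in this assay. They also leave open what a longer chain in the linker leading out to the amine nitrogen would do, and whether a (4-chlorophenyl)carbonyl group would read any differently from the two groups tested.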